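The source may report more compounds than this note shows. Statements on the series, on what has been measured and on what is new or still open speak of the compounds shown alone.

Compounds measured so far:
compound 1, `CCCCOC(=O)NS(=O)(=O)c1ccc(CCC)cc1-c1ccc(Cn2c(-c3ccccc3)nc3ccccc32)cc1`, 590 nM
compound 2, `CCCCOC(=O)NS(=O)(=O)c1ccc(CCC)cc1-c1ccc(Cn2c(C3CCC3)nc3ccccc32)cc1`, 12 nM
compound 3, `CCCCOC(=O)NS(=O)(=O)c1ccc(CCC)cc1-c1ccc(Cn2c(CCC)nc3ccccc32)cc1`, 14 nM

In an assay on membranes from HEK293 cells for displacement of a labelled ligand from Type-2 angiotensin II receptor (Homo sapiens), read by radioligand binding (on this read-out lower numbers stand for stronger inhibition and higher numbers for weaker inhibition), compound 3 lies far from compound 1, with a 42-fold lower number from compound 1 to compound 3 (1.62 log units; beyond the scatter), while the other measured step is much smaller: a 1.2-fold higher number from compound 2 to compound 3 (0.07 log units; within the scatter). The unmeasured compound 4, `CCCCOC(=O)NS(=O)(=O)c1ccc(CCC)cc1-c1ccc(Cn2c(C3CC3)nc3ccccc32)cc1`, differs from compound 3 by cyclopropyl in place of propyl on an aromatic carbon. Going by the values given here, two measured steps bear on this change: a 49-fold lower number from compound 1 to compound 2 (1.69 log units; beyond the scatter) and a 1.2-fold higher number from compound 2 to compound 3 (0.07 log units; within the scatter). A cyclobutyl and a propyl at this carbon gave numbers within the scatter of each other, and a cyclopropyl is another small saturated carbon group at the same place. No step beyond the scatter is therefore expected in this assay from compound 3 to compound 4; the expected step is no change at the digits printed from compound 3 to compound 4 (within the scatter). Compound 4 is estimated at 14 nM, in a range from 5 nM to 40 nM.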

Compound 4, inhibition constant: 31 nM
Compound 4: middle estimate off by 2.2-fold (0.35 log units), on the low side; measured number inside the range.
By their numbers in this assay, from the lowest: compounds 2 and 3 (each within the scatter of the next); then compound 4; then compound 1.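

In this assay, the carbon between two ring nitrogen atoms did not treat all small saturated carbon groups alike: cyclopropyl for propyl, with the same heavy-atom count, gave a 2.2-fold higher number from compound 3 to compound 4 (0.35 log units; beyond the scatter) and cyclopropyl for cyclobutyl gave a 2.6-fold higher number from compound 2 to compound 4 (0.41 log units; beyond the scatter) in this series. Even so, the cyclopropyl group stayed well clear of the phenyl group, with a 19-fold lower number from compound 1 to compound 4 (1.28 log units; beyond the scatter) on this read-out. No measurement offered here accounts for these steps. The compounds shown leave open how a longer chain such as butyl, a cyclopentyl ring or an amine would fare at this carbon.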